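The source may hold more compounds than are shown below. What is called first, only, known or untested is meant among the compounds shown, and "the series" means these compounds.

Working notes on the series. Compound 1 `COC1Cc2c(csc2-c2ccc(C(C)=O)cc2)C2(CCN(Cc3ccccc3)CC2)O1` and compound 2 `COC1Cc2c(csc2-c2ccc(C#N)cc2)C2(CCN(Cc3ccccc3)CC2)O1` share one core; compound 3 `COC1Cc2cc(-c3ccc(C(C)=O)cc3)sc2C2(CCN(Cc3ccccc3)CC2)O1` carries the same atoms joined differently, and the difference between the two cores is not broken down here. In an assay on membranes from brain for displacement of a labelled ligand from Sigma non-opioid intracellular receptor 1 (Cavia porcellus), read by scintillation counting, with a stated time of 120 min (a higher number here means a weaker inhibitor, a lower number a stronger inhibitor), compound 1 gives 1.6 nM, and compound 2 gives 0.25 nM. The change between them, (cyano in place of acetyl on an aromatic carbon), made the step of a 6.4-fold lower number from compound 1 to compound 2 (0.81 log units; beyond the scatter). In this assay compound 3 gives 59 nM, the highest number of the three measured compounds, well beyond the scatter from compound 1 and from compound 2.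

Compound 4 `COC1Cc2cc(-c3ccc(C#N)cc3)sc2C2(CCN(Cc3ccccc3)CC2)O1` has not yet been measured. Within the data shown here, it differs from compound 3 by cyano in place of acetyl on an aromatic carbon, which is the same change as the one from compound 1 to compound 2, in the same kind of place. Among the measured compounds shown here, the expectation is that compound 4 gives a step of about a 5.9-fold lower number from compound 3 to compound 4 (0.77 log units; beyond the scatter), because the same change gave a 6.4-fold lower number from compound 1 to compound 2 (0.81 log units; beyond the scatter) on the other core, though only one such pair supports this. Compound 4 is therefore estimated at 10 nM, with an expected range from 3 nM to 30 nM.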

Compound 4, inhibition constant: 20 nM
Compound 4: middle estimate off by 2.0-fold (0.30 log units), on the low side; the range from low to high includes it.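

In this assay, cyano in place of acetyl on the second core gave a 3.0-fold lower number from compound 3 to compound 4 (0.47 log units; beyond the scatter), so the number falls on this core as it did on the first. Set beside the earlier step, the size of the change does not differ beyond what repeated measurements would allow: the same change on two cores in this assay, a 6.4-fold lower number (0.81 log units; beyond the scatter) from compound 1 to compound 2 and a 3.0-fold lower number (0.47 log units; beyond the scatter) from compound 3 to compound 4, 2.2-fold (0.34 log units) apart, within the scatter of two such steps. The change therefore carried over between these two cores in direction and, within the scatter, in size, but two pairs set no rule for any further core, and they neither explain the step nor break down the difference between the two cores.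

The compounds shown leave open whether a carboxylic acid, an amine or a longer chain at the same place on the six-membered aromatic ring would also carry over between the two cores. Also open, as far as these compounds go, is whether the agreement between the two steps holds for any read-out other than this assay.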